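Cyclopentyl for methyl on the indole nitrogen

The compounds below may be only part of what the source reports. "The series", "measured", "known", "first", "only" and "open" are said of these compounds alone.

Measured compounds:
Compound 1 `Oc1ccccc1Nc1nccc(-c2c[nH]c3ccccc23)n1`, 120 nM
Compound 2 `COCCSc1nc(C)c(-c2ccnc(Nc3ccc(OC)cc3OC)n2)s1`, 1700 nM
Compound 3 `COc1ccc(Nc2nccc(-c3cn(C)c4ccccc34)n2)c(OC)c1`, 610 nM

In an assay for inhibition of MAP kinase-interacting serine/threonine-protein kinase 2 (Homo sapiens), read by TR-FRET (on this read-out lower numbers stand for stronger inhibition and higher numbers for weaker inhibition), compound 3 stands second highest of the three numbers; compound 2 gives a higher number, beyond the scatter, and compound 1 a lower one, also beyond the scatter. Compound 4 `COc1ccc(Nc2nccc(-c3cn(C4CCCC4)c4ccccc34)n2)c(OC)c1` has not yet been measured in this assay. It differs from compound 3 by cyclopentyl in place of methyl on an aromatic nitrogen. For the measured compounds named here, no pair of measured compounds shows this change, so its effect is unknown from the present numbers. The author expects a small step from compound 3 to compound 4, a 1.7-fold lower number from compound 3 to compound 4 (0.24 log units; within the scatter), towards a lower number, though it could fall within the scatter. The value expected for compound 4 is 350 nM, with a range from 80 nM to 1500 nM.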

Compound 4, inhibition constant: 390 nM
Compound 4: the middle estimate sits 1.1-fold (0.05 log units) below what was measured; the range from low to high includes it.
By their numbers in this assay, from the lowest: compound 1; then compounds 4 and 3 (each within the scatter of the next); then compound 2.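

Exchanging methyl for cyclopentyl on the aromatic nitrogen, which raises the group from 1 heavy atom to 5, gives in this assay a step of a 1.6-fold lower number from compound 3 to compound 4 (0.19 log units; within the scatter) and so leaves the number within the scatter. At this position, then, the read-out does not separate a small methyl from a cyclopentyl ring of carbon only. No available evidence bears on this result. Still open, on these data alone, is whether a longer chain, an amine or a carboxylic acid on this nitrogen would move the number beyond the scatter.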